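A few compounds are considered here, and "the series" means these few. Any claim that something is new, unique, unknown or untested is made for them only; others in the source may bear on it.

Measured in a functional assay on HT-29 cells (Homo sapiens) for inhibition, read by MTT assay, with a stated time of 72 h; on this read-out higher numbers stand for weaker inhibition and lower numbers for stronger inhibition:

- Compound 1 `C=C(Br)C(=O)Nc1cccc(/C=C/C(=O)Nc2cccc3ccccc23)c1`: 6500 nM
- Compound 2 `C=C(Br)C(=O)Nc1cccc(/C=C/C(=O)Nc2ccc(F)cc2)c1`: 36600 nM

Of these two numbers, compound 2 holds the higher one, 36600 nM here, so it is the weaker inhibitor of the pair, and its gap to compound 1 lies beyond the usual scatter. Compound 3 `C=C(Br)C(=O)Nc1cccc(/C=C/C(=O)Nc2ccc(F)c(F)c2)c1` is compound 2 with a single change: fluoro in place of hydrogen on an aromatic carbon turns 4-fluorophenyl into 3,4-difluorophenyl, with fluoro in place of hydrogen on an aromatic carbon, ortho to a fluoro group. Among the compounds with values here, no measured pair shows a single change of this kind, so the data offer no direct guide. One added fluoro is a small edit, so only a small step toward stronger inhibition is expected, possibly none beyond the scatter. The expected step is a 1.4-fold lower number from compound 2 to compound 3 (0.15 log units; within the scatter). The estimated value for compound 3 is 26000 nM, with a likely range from 11000 nM to 60000 nM.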

Compound 3, half-maximal inhibitory concentration: 8700 nM
Beside the measured number, compound 3's estimate is 3.0-fold (0.48 log units) above it; measured number outside the range, below it.
By their numbers in this assay, from the lowest: compounds 1 and 3 (each within the scatter of the next); then compound 2.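

In this assay there is a 4.2-fold lower number from compound 2 to compound 3 (0.62 log units; beyond the scatter) when 4-fluorophenyl becomes 3,4-difluorophenyl, so one added fluoro, ortho to a fluoro group and meta to a large group, is enough to shift the number beyond the usual scatter. This is the first one-place change among the compounds shown, and it reveals that this position on the aromatic ring is sensitive to substitution, even when the edit adds only a single heavy atom. Nothing at hand explains why the number falls.

The compounds shown leave open whether another group at this position, such as chloro, methoxy or an amine, would move the number as far as fluoro does. They also leave open whether the added fluoro would have the same effect on a ring without the first fluoro group.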